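Adding a further methoxy group to compound 3

This account rests on a few compounds, and the source may have more. Where it says the series, first, only, none or still open, it means among the compounds named here.

In a functional assay on HCT-116 cells (Homo sapiens) for antiproliferative activity, read by sulforhodamine B assay, with a stated time of 48 h (on this read-out lower numbers stand for stronger inhibition of growth and higher numbers for weaker inhibition of growth), compound 1 (`Cc1ccc(C(=O)c2ccc3nc(/C=C/C(=O)NO)ccc3c2)cc1`) gives 2510 nM, compound 2 (`COc1ccc(C(=O)c2ccc3nc(/C=C/C(=O)NO)ccc3c2)cc1`) gives 2300 nM and compound 3 (`COc1ccc(C(=O)c2ccc3nc(/C=C/C(=O)NO)ccc3c2)cc1OC`) gives 1780 nM. Compound 3 stands within the scatter of both other compounds, so these three values support no ranking.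

Compound 4 (`COc1cc(C(=O)c2ccc3nc(/C=C/C(=O)NO)ccc3c2)cc(OC)c1OC`) differs from compound 3 by methoxy in place of hydrogen on an aromatic carbon. Going by the values given here, the closest precedent is the same replacement, which gave a 1.3-fold lower number from compound 2 to compound 3 (0.11 log units; within the scatter). Methoxy in place of methyl gave a 1.1-fold lower number from compound 1 to compound 2 (0.04 log units; within the scatter). Both steps lie within the scatter, so neither establishes a real trend. A small move toward a lower number in this assay is expected, but nothing beyond the scatter. The estimated step is a 1.4-fold lower number from compound 3 to compound 4 (0.14 log units; within the scatter). With so few compounds, the range is kept wide, especially on the lower side. For compound 4, the estimated value is 1300 nM, with an expected range of 400 nM to 3000 nM.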

Compound 4, concentration for 50% growth inhibition: 2620 nM
Estimate against measurement, compound 4: 2.0-fold (0.30 log units) below; the measured number falls inside the stated range.
By their numbers in this assay, from the lowest: compounds 3, 2, 1 and 4 (each within the scatter of the next).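

In this assay, a third methoxy on the aromatic ring, ortho to a methoxy group and meta to a large group, gives a 1.5-fold higher number from compound 3 to compound 4 (0.17 log units; within the scatter), while the same replacement earlier gave a 1.3-fold lower number from compound 2 to compound 3 (0.11 log units; within the scatter). The two steps carry opposite signs, yet both lie within the scatter, so methoxy in place of hydrogen has no established direction in this set, and this position accepts the extra methoxy without a shift beyond the scatter. No available measurement bears on the reason for this result.

From the compounds shown here alone, whether any group at this aromatic carbon can move the number beyond the scatter stays open. An amine, a carboxylic acid or a longer chain such as ethoxy would test this, as the methoxy, methyl and hydrogen cases shown do not settle it.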